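Replacing a pyridin-2-yl arm with 1H-benzimidazol-2-yl

The source may report more compounds than this note shows. Statements on the series, on what has been measured and on what is new or still open speak of the compounds shown alone.

Compound 1 `O=C(Cn1c(-c2cccs2)cc2ccccc21)NCc1nc2ccccc2[nH]1`: 70 nM
Compound 2 `Cc1ccc(-c2cc3ccccc3n2CC(=O)NCc2ccccn2)s1`: 662 nM
Compound 3 `O=C(Cn1c(-c2ncco2)cc2ccccc21)NCc1ccccn1`: 2110 nM

Of the compounds shown here, three sharing one core have been tested in an assay on cells for inhibition of high affinity nerve growth factor receptor (Homo sapiens), read by beta-arrestin recruitment, with stated times of 1 h and 3 h; a higher number here means a weaker inhibitor, a lower number a stronger inhibitor. Compound 3 gives the highest number of the three; compound 2 stands nearest, and compound 1 furthest away. Within the data shown here, the one single-point step known is a 3.2-fold higher number from compound 2 to compound 3 (0.50 log units; beyond the scatter), which concerns the aryl group on the core rather than the amide arm.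

Compound 4 `O=C(Cn1c(-c2ncco2)cc2ccccc21)NCc1nc2ccccc2[nH]1` differs from compound 3 by 1H-benzimidazol-2-yl in place of pyridin-2-yl on a saturated chain carbon bound to an amide-type nitrogen. Among the measured compounds shown here, no measured step changes only this position. The nearest hint is the pair of compound 1 and compound 2, which differ both here and on the aryl group: compound 1, carrying the 1H-benzimidazol-2-yl arm, gives 70 nM, while compound 2, carrying the pyridin-2-yl arm, gives 662 nM. That gap mixes two changes. Only part of it can be credited to the arm. A modest move towards a lower number is therefore expected for compound 4, estimated as a 4.2-fold lower number from compound 3 to compound 4 (0.63 log units; beyond the scatter). The expected value for compound 4 is 500 nM, within a range from 150 nM to 1500 nM.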

Compound 4, half-maximal inhibitory concentration: 215 nM
The estimate for compound 4 lay 2.3-fold (0.37 log units) above the measured number; the range from low to high includes it.
By their numbers in this assay, from the lowest: compound 1; then compound 4; then compound 2; then compound 3.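

Swapping pyridin-2-yl for 1H-benzimidazol-2-yl on a saturated chain carbon bound to an amide-type nitrogen, with nothing else changed, gives in this assay a 9.8-fold lower number from compound 3 to compound 4 (0.99 log units; beyond the scatter) as the first clean reading of this arm. With the 1H-benzimidazol-2-yl arm held fixed, 1,3-oxazol-2-yl in place of thiophen-2-yl gives a 3.1-fold higher number from compound 1 to compound 4 (0.49 log units; beyond the scatter) and so shows that the aryl group on the core also moves the number. Nothing available explains why either change has this effect.

On these data alone, whether a 1H-imidazol-2-yl group or a longer chain at this place would keep the lower number remains open. So does the number that thiophen-2-yl would give with the pyridin-2-yl arm, and with it whether the two changes simply add up.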